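The source may report more compounds than this note shows. Statements on the series, on what has been measured and on what is new or still open speak of the compounds shown alone.

Of the compounds shown here, three on a shared core have been measured in a functional assay on the whole organism (strain Swiss) with Mus musculus as the target, in the maximal electroshock model, with a stated time of 0.25 h, at a dose of 100 mg/kg by the intraperitoneal route; on this read-out higher numbers stand for a stronger effect at the one dose given and lower numbers for a weaker effect. Compound 1 `COCC(C(=O)N1CCN(c2cccc(C(F)(F)F)c2)CC1)N1C(=O)CCC1=O` gives 100% there. Compound 2 `CC(C(=O)N1CCN(c2ccccc2)CC1)N1C(=O)CCC1=O` gives 50%. Compound 3 `CCC(C(=O)N1CCN(c2cccc(F)c2)CC1)N1C(=O)CCC1=O` gives 0%. Compound 2 thus stands second highest of the three numbers, below compound 1 and above compound 3, with both gaps lying beyond the scatter. Compound 4 `CC(C(=O)N1CCN(c2ccccc2F)CC1)N1C(=O)CCC1=O` has not yet been measured. It differs from compound 2 by fluoro in place of hydrogen on an aromatic carbon; cut one bond further out, the change reads phenyl to 2-fluorophenyl. Within the data shown here, no measured pair differs in one place alone, so no step bears directly on this change, and compounds 1 and 3 each differ from compound 2 in more than one place. A step of a number 10 percentage points lower from compound 2 to compound 4 (within the scatter) is expected in this assay, none beyond the scatter. Compound 4 is estimated at 40%, with a range from 0% to 90%.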

Compound 4, a percentage reported as activity, at one dose (the size of the read-out at that dose, not a potency): 75%
Beside the measured number, compound 4's estimate is 35 percentage points below it; the range from low to high includes it.
By their numbers in this assay, from the lowest: compound 3; then compound 2; then compound 4; then compound 1.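

In this assay, fluoro in place of hydrogen on an aromatic carbon, ortho to a large group, gives a number 25 percentage points higher from compound 2 to compound 4 (beyond the scatter). Among these compounds, this is the first change that can be read at one place alone, and it shows that this position tolerates fluoro without loss of effect at the one dose given. No measurement shown accounts for the step.

As far as these compounds go, whether chloro, methoxy or a nitrile at the same place would give a similar step remains open. So does whether fluoro on another aromatic carbon would do so.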